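From Nitrophenyl Ketone to Thiophen-2-yl Ketone

A few compounds are considered here, and "the series" means these few. Any claim that something is new, unique, unknown or untested is made for them only; others in the source may bear on it.

Of the compounds shown here, two that share one core have been measured so far. Compound 1 `COc1ccc(-c2cc3ccccc3nc2/C=C/C(=O)c2ccc(OC)c(OC)c2)cc1` carries a 3,4-dimethoxyphenyl on its carbonyl carbon, and in a functional assay on NCI-H460 cells (Homo sapiens) for antiproliferative activity, read by XTT assay, with a stated time of 72 h (a higher number here means a weaker inhibitor, a lower number a stronger inhibitor), compound 1 gives 7540 nM. Compound 2 `COc1ccc(-c2cc3ccccc3nc2/C=C/C(=O)c2ccc([N+](=O)[O-])cc2)cc1` has a 4-nitrophenyl on that carbonyl carbon instead, and in this assay compound 2 gives 6470 nM. The step of a 1.2-fold lower number from compound 1 to compound 2 (0.07 log units; within the scatter) shows that this exchange on the carbonyl carbon left the number essentially where it was. On the numbers shown, compound 2 and compound 1 stand side by side, their gap lying inside the scatter, so no order between them can be claimed.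

Compound 3 `COc1ccc(-c2cc3ccccc3nc2/C=C/C(=O)c2cccs2)cc1` is the next variation: thiophen-2-yl in place of 4-nitrophenyl on a carbonyl carbon. Going by the values given here, only one measured step bears on this change, the step from compound 1 to compound 2, which also exchanged the group on the carbonyl carbon and stayed within the scatter. A change at the same place is therefore expected to move this assay little, if at all. For compound 3 the expected step is a 1.0-fold higher number from compound 2 to compound 3 (0.00 log units; within the scatter). Compound 3 is expected to give about 6500 nM, within a range of 2500 nM to 17000 nM.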

Compound 3, half-maximal inhibitory concentration: 5440 nM
Estimate against measurement, compound 3: 1.2-fold (0.08 log units) above; low and high end bracket the measured number.
By their numbers in this assay, from the lowest: compounds 3, 2 and 1 (each within the scatter of the next).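

Compound 3 shows that in this assay the place on the carbonyl carbon can hold a five-membered aromatic ring with a sulfur atom as well as a six-membered ring of carbon only: thiophen-2-yl, with 5 heavy atoms, replaces 4-nitrophenyl, with 9, and the result is a 1.2-fold lower number from compound 2 to compound 3 (0.08 log units; within the scatter) for this exchange. Set against the 3,4-dimethoxyphenyl group, the same ring gives a 1.4-fold lower number from compound 1 to compound 3 (0.14 log units; within the scatter) and so also stays level, which means that no order among the three groups can be claimed. Across these three compounds, neither the change of ring size nor the change from a carbon-only ring to a sulfur-containing ring separates the numbers. Nothing further is available here that would explain why the three numbers lie so close together.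

All three groups are aromatic rings, so the compounds shown leave open what an amine, a carboxylic acid or a longer alkyl chain on this carbonyl carbon would do. They also leave open whether a change elsewhere on the shared core would move the number beyond the scatter.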